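The compounds below may be only part of what the source reports. "The series", "measured", "known", "first", "only" and "open" are said of these compounds alone.

Two compounds with measured activity frame the question. Compound 1, `O=c1ccn([C@]23CC2[C@H](COP(=O)(O)OP(=O)(O)O)[C@@H](O)C3)c(=O)[nH]1`, and compound 2, `C=CCSc1ccn([C@@H]2O[C@H](COP(=O)(O)OP(=O)(O)O)[C@@H](O)[C@H]2O)c(=O)n1`, were both tested in an in vitro functional assay on 1321-N1 cells for agonist activity at P2Y purinoceptor 6 (Homo sapiens); on this read-out higher numbers stand for an effect only at larger amounts of compound and lower numbers for an effect already at smaller amounts. In this assay compound 1 gives 230 nM, and in this assay compound 2 gives 560 nM. Of these two numbers compound 2 has the higher one, so it acts only at a larger amount than compound 1, and that gap lies beyond the usual scatter.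

Compound 3, `CCSc1ccn([C@@H]2O[C@H](COP(=O)(O)OP(=O)(O)O)[C@@H](O)[C@H]2O)c(=O)n1`, has not yet been measured. It differs from compound 2 in a single place: methyl in place of vinyl on a saturated chain carbon bound to a sulfur. Among the measured compounds shown here, no measured pair shows that same change, so its effect cannot be read from earlier numbers; it is a modest trimming of a side chain. For compound 3 the expected step is a 1.1-fold higher number from compound 2 to compound 3 (0.03 log units; within the scatter), small enough to stay within the scatter and with no clear direction. Compound 3 is therefore estimated in this assay at 600 nM, with a range from 250 nM to 1500 nM.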

Compound 3, half-maximal effective concentration: 280 nM
Estimate against measurement, compound 3: 2.1-fold (0.33 log units) above, and the stated range covers the measured number.
By their numbers in this assay, from the lowest: compounds 1, 3 and 2 (each within the scatter of the next, the first and the last beyond it).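

In this assay, among the compounds shown here, the change from allyl to ethyl on the sulfur gives a 2.0-fold lower number from compound 2 to compound 3 (0.30 log units; within the scatter), the first direct comparison of two compounds that differ in one place. Removing one carbon and the double bond outside aromatic rings therefore produces no difference that can be told apart from ordinary measurement scatter, so at this position the double bond is not needed to keep activity at this level. Nothing available on these compounds gives a reason for this result.

What the pair leaves open is how much further this side chain can be changed: a shorter methyl group, a longer chain such as butyl, or a benzyl group could each behave differently. An amine or a carboxylic acid at the end of the chain also remains untested within the compounds shown.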